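Swapping an Ethylcarbamoyl for a Phenylsulfonyl Group

The source may hold more compounds than are shown below. What is called first, only, known or untested is meant among the compounds shown, and "the series" means these compounds.

Measured compounds in an ADME assay on Caco-2 cells (Homo sapiens) for permeability, in the apical to basolateral direction; on this read-out higher numbers stand for higher permeability and lower numbers for lower permeability:
Compound 1 `Cn1cncc1CN1CC(N(CC2CCN(C(=O)CC(C)(C)C)CC2)S(=O)(=O)c2ccccn2)Cc2cc(C#N)ccc21` gives 0.5 10^-6 cm/s.
Compound 2 `CCNC(=O)N1CCC(CN(C2Cc3cc(C#N)ccc3N(Cc3cncn3C)C2)S(=O)(=O)c2ccccn2)CC1` gives 0.6 10^-6 cm/s.

Among the compounds with values here, compound 2 stands highest of the two numbers, but its only neighbour, compound 1, sits within the scatter of it, so the two cannot be told apart. Within the data shown here, the single measured step, a 1.2-fold higher number from compound 1 to compound 2 (0.08 log units; within the scatter), shows that changing the group on the carbonyl carbon of the piperidine nitrogen left this assay unchanged.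

Compound 3 `Cn1cncc1CN1CC(N(CC2CCN(S(=O)(=O)c3ccccc3)CC2)S(=O)(=O)c2ccccn2)Cc2cc(C#N)ccc21` has not yet been measured. It differs from compound 2 thus: phenylsulfonyl in place of ethylcarbamoyl on an amine nitrogen in a ring. Among the measured compounds shown here, no measured step covers an exchange of this kind; the step from compound 1 to compound 2 only shows that this position tolerated one alteration without a visible effect. A change at the same nitrogen is therefore expected to move this assay little, a 1.3-fold higher number from compound 2 to compound 3 (0.12 log units; within the scatter), with wide uncertainty.

Compound 3 is estimated at 0.8 10^-6 cm/s, within 0.3 10^-6 cm/s to 2.5 10^-6 cm/s.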

Compound 3, apparent permeability: 0.1 10^-6 cm/s
Estimate against measurement, compound 3: 8.0-fold (0.90 log units) above, and the stated range ends above it.
By their numbers in this assay, from the lowest: compound 3; then compounds 1 and 2 (each within the scatter of the next).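

In this assay, a 6.0-fold lower number from compound 2 to compound 3 (0.78 log units; beyond the scatter) and a 5.0-fold lower number from compound 1 to compound 3 (0.70 log units; beyond the scatter) show that the amine nitrogen in the six-membered non-aromatic ring is not indifferent to what it carries. The earlier exchange on the carbonyl carbon stayed within the scatter, but that tolerance did not extend to phenylsulfonyl taking the place of either carbonyl-linked group. Nothing measured here bears on what lies behind the lower number.

The compounds shown leave open whether the drop goes with the sulfonyl link or with the phenyl ring, a question that a benzoyl group or a methylsulfonyl group on this nitrogen would address. Nor do they show how this assay reads with a free amine at this nitrogen.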